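Methyl for Methoxy on the Outer Phenyl Ring

This account rests on a few compounds, and the source may have more. Where it says the series, first, only, none or still open, it means among the compounds named here.

Measured in a functional assay on NCI-H460 cells (Homo sapiens) for cytotoxicity, read by MTT assay, with a stated time of 72 h; on this read-out higher numbers stand for weaker inhibition and lower numbers for stronger inhibition:
Compound 1 `COc1ccc(-c2ccnc(C(=O)Nc3ccc(Oc4ccnc5cc(OCCCN6CCCCC6)c(OC)cc45)c(F)c3)c2)cc1`: 200 nM
Compound 2 `COc1ccc(-c2ccnc(C(=O)Nc3ccc(Oc4ccnc5cc(OCCCN6CCN(C)CC6)c(OC)cc45)c(F)c3)c2)cc1`: 370 nM
Compound 3 `COc1ccc(-c2ccnc(C(=O)Nc3ccc(Oc4ccnc5cc(OCCCN6CCCC6)c(OC)cc45)c(F)c3)c2)cc1`: 200 nM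

Compound 1 stands level with compound 3, the two together being the lowest numbers of the three (no change at the digits printed from compound 1 to compound 3 (within the scatter)), and its gap to compound 2 is small (a 1.9-fold higher number from compound 1 to compound 2 (0.27 log units; within the scatter)). Compound 4 `COc1cc2c(Oc3ccc(NC(=O)c4cc(-c5ccc(C)cc5)ccn4)cc3F)ccnc2cc1OCCCN1CCCCC1` differs from compound 1 by methyl in place of methoxy on an aromatic carbon. Every measured step swaps only the amine at the end of the chain on the shared core and leaves the outer phenyl ring untouched, so none of them bears on this change; no precedent for it exists among these compounds. The expectation is therefore a step of a 1.3-fold higher number from compound 1 to compound 4 (0.10 log units; within the scatter) that stays within the scatter, held with low confidence. Compound 4 is estimated at 250 nM in this assay, with a range from 90 nM to 700 nM.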

Compound 4, half-maximal inhibitory concentration: 160 nM
The estimate for compound 4 lay 1.6-fold (0.19 log units) above the measured number; the measured number falls inside the stated range.
By their numbers in this assay, from the lowest: compounds 4, 1, 3 and 2 (each within the scatter of the next, the first and the last beyond it).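

Among these compounds, this is the first change on the outer phenyl ring rather than at the amine end of the chain. In this assay, going from 4-methoxyphenyl to 4-methylphenyl gives a 1.3-fold lower number from compound 1 to compound 4 (0.10 log units; within the scatter), so at this place, para to a large group, the methoxy oxygen and its hydrogen-bond acceptor can go without a shift beyond the scatter. No measurement available here offers an explanation for this result. Still open, as far as these compounds go, is whether a chlorine atom, a trifluoromethyl or a hydroxyl at this place would do the same. From the compounds shown here alone, it is also open whether the methyl behaves alike with the pyrrolidin-1-yl of compound 3.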